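Hydroxy to amino on the fused-ring core

The compounds below may be only part of what the source reports. "The series", "measured", "known", "first", "only" and "open" are said of these compounds alone.

Measured compounds:
compound 1 `CC(=O)Nc1cccc2c1CCCC2c1c[nH]cn1` — 3020 nM
compound 2 `Oc1cccc2c1CCCC2c1c[nH]cn1` — 3.8 nM

In an assay on isolated protein for binding affinity to Alpha-2B adrenergic receptor (Rattus norvegicus), read by radioligand binding (a lower number here means a stronger inhibitor, a higher number a weaker inhibitor), compound 2 gives the lowest of the two numbers; its nearest neighbour is compound 1, and the step of a 790-fold lower number from compound 1 to compound 2 (2.90 log units; beyond the scatter) is large and beyond the scatter. Compound 3 `Nc1cccc2c1CCCC2c1c[nH]cn1` is not yet measured. It differs from compound 2 in one place: amino in place of hydroxy on an aromatic carbon. For the measured compounds named here, no measured step covers this exact exchange. Going by the values given here, the only step on the shared core, a 790-fold lower number from compound 1 to compound 2 (2.90 log units; beyond the scatter), shows that what sits on this aromatic carbon can move this assay by a great deal, but it does not say how amino compares with hydroxy. The change is expected to cost some affinity, with a step of a 5.3-fold higher number from compound 2 to compound 3 (0.72 log units; beyond the scatter) expected, though whether it clears the scatter is uncertain. Compound 3 is expected to give about 20 nM, in a range from 4 nM to 100 nM.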

Compound 3, inhibition constant: 49 nM
Compound 3: middle estimate off by 2.5-fold (0.39 log units), on the low side; low and high end bracket the measured number.
By their numbers in this assay, from the lowest: compound 2; then compound 3; then compound 1.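

In this assay, amino in place of hydroxy on this aromatic carbon gives a 13-fold higher number from compound 2 to compound 3 (1.11 log units; beyond the scatter), so the two groups are not interchangeable here, although each counts as one hydrogen-bond donor and one hydrogen-bond acceptor. Hydrogen in place of acetyl on the nitrogen gives a 62-fold lower number from compound 1 to compound 3 (1.79 log units; beyond the scatter), which shows that the acetyl goes with a large part of the weak binding of compound 1, and that the free amino group does not recover all of the distance to the hydroxy of compound 2. Nothing available accounts for the gap between hydroxy and amino at this position.

Open, on these data alone, is where a methoxy or a methylamino group on the same aromatic carbon would fall relative to hydroxy and amino. Also open, as far as these compounds go, is whether a sulfonamide on the nitrogen would behave like the acetamido group.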